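This account rests on a few compounds, and the source may have more. Where it says the series, first, only, none or still open, it means among the compounds named here.

In a functional assay on U-87MG ATCC cells for inhibition, with U-87 MG (Homo sapiens) as the target, read by MTT assay, with a stated time of 48 h (on this read-out lower numbers stand for stronger inhibition and higher numbers for weaker inhibition), compound 1 (`Cc1ccc(-c2nc3ccccn3c2Sc2ccccc2)cc1`) gives > 100000 nM as a limit of the assay and not as a number. Compound 2 (`c1ccc(Sc2c(-c3ccccc3)nc3ccc(-c4ccccc4)cn23)cc1`) gives > 100000 nM as a limit too. Compound 1 thus has no exact rank (it stands at (the limit of > 100000 nM in this assay, at which 2 of the 3 values shown sit)). Compound 3 (`Cc1ccc(-c2nc3ccc(C)cn3c2Sc2ccccc2)cc1`) gives 82100 nM as a measured number.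

The step followed here leads to compound 4 (`Clc1ccc(-c2nc3ccccn3c2Sc2ccccc2)cc1`), with chloro in place of methyl on an aromatic carbon. In other words, 4-methylphenyl becomes 4-chlorophenyl, on an aromatic carbon of a six-membered aromatic ring of carbon only, para to a large group.

Within the data shown here, one measured step bears on this, and only loosely: an at least 1.2-fold lower number from compound 1 to compound 3 (0.08 log units; that floor lies within the scatter) for methyl in place of hydrogen on an aromatic carbon. Among the measured compounds shown here, that step leaves the 4-methylphenyl group unchanged, and no measured step swaps the group that changes here. With only this to go on, no step beyond the scatter is expected in this assay and no direction is favoured. The estimated change is an at least 1.1-fold lower number from compound 1 to compound 4 (0.04 log units; that floor lies within the scatter) and it stays a rough expectation. Compound 4 is expected at 90000 nM with an estimated range (40000 nM to 150000 nM).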

Compound 4, half-maximal inhibitory concentration: 30200 nM
Beside the measured number, compound 4's estimate is 3.0-fold (0.47 log units) above it, outside the stated range (below it).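

Chloro in place of methyl, on an aromatic carbon para to a large group, gives an at least 3.3-fold lower number from compound 1 to compound 4 (0.51 log units; beyond the scatter) in this assay. This place on the core can therefore move the read-out by more than the scatter, which an at least 1.2-fold lower number from compound 1 to compound 3 (0.08 log units; that floor lies within the scatter), a change made elsewhere on the core, did not show, and compound 4 at 30200 nM gives the series a second measured number to work from. The printed size is only a floor, because compound 1 gives a limit of the assay and not a number: the limit of > 100000 nM in this assay, at which 2 of the 4 values shown sit.

Only methyl and chloro are compared at this place, so it remains open how a bromo, a methoxy, an amine or a carboxylic acid there would read, and the compounds shown offer no measured basis for a cause of the step. As far as these compounds go, whether chloro gives a similar step on the core of compound 3, which carries the added methyl, also remains open, as does whether any change at this place can take the numbers much lower than that of compound 4.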